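The source may hold more compounds than are shown below. What is called first, only, known or untested is meant among the compounds shown, and "the series" means these compounds.

Compound 1 `N#Cc1cnc(NCc2cnccc2C(F)(F)F)cc1N[C@H]1C[C@H](O)C1`: 96%
Compound 2 `N#Cc1cnc(NCc2cnccc2C(F)(F)F)cc1NC[C@H]1CC[C@H](O)CC1`: 32%

In an ADME assay on S9 fraction from liver (Homo sapiens) for metabolic stability, with a stated time of 1 h (a higher number here means that more of the compound is left, a lower number that less of the compound is left), compound 2 stands lower of the two measured compounds, at 32%, while compound 1 gives 96%. The next compound, compound 3 `CNC(=O)[C@H]1CC[C@@H](Nc2cc(NCc3cnccc3C(F)(F)F)ncc2C#N)CC1`, differs from compound 2 on a nitrogen on an aromatic ring, where 4-(methylcarbamoyl)cyclohexyl takes the place of (4-hydroxycyclohexyl)methyl: 4-(methylcarbamoyl)cyclohexyl in place of (4-hydroxycyclohexyl)methyl on a nitrogen on an aromatic ring. Among the measured compounds shown here, only one measured step bears on this change: a number 64 percentage points lower from compound 1 to compound 2 (beyond the scatter). That step is large and falls at the same place. Like the 3-hydroxycyclobutyl of compound 1, the entering group has no methyl link in its name, but no measured compound carries it, so the read-across is loose. A sizeable rise is therefore expected, probably short of the full size of the measured step. The expected change is a number 36 percentage points higher from compound 2 to compound 3 (beyond the scatter). Compound 3 is estimated at 68%, within a range of 40% to 92%.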

Compound 3, percent of the compound remaining: 71%
Compound 3: middle estimate off by 3 percentage points, on the low side, within the range that was stated.
By their numbers in this assay, from the lowest: compound 2; then compound 3; then compound 1.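

At this position on a nitrogen on an aromatic ring, a six-membered non-aromatic ring of carbon only does not by itself settle the result in this assay: 4-(methylcarbamoyl)cyclohexyl and (4-hydroxycyclohexyl)methyl both carry such a ring, yet the exchange gives a number 39 percentage points higher from compound 2 to compound 3 (beyond the scatter). The small 3-hydroxycyclobutyl still holds the top place, with a number 25 percentage points lower from compound 1 to compound 3 (beyond the scatter), so the larger group recovers much of the loss seen with compound 2 but not all of it. Nothing available explains either step.

The exchange removes the methyl link and replaces the hydroxyl with methylcarbamoyl at once, so the compounds shown leave open which of the two matters. A 4-hydroxycyclohexyl group on the same nitrogen would separate them, and a 3-(methylcarbamoyl)cyclobutyl group would test the amide on the smaller ring.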